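Trifluoromethyl in Place of Methoxy: What to Expect for Compound 3

The source may hold more compounds than are shown below. What is called first, only, known or untested is meant among the compounds shown, and "the series" means these compounds.

Of the compounds shown here, two sharing one core have been measured in an assay on NIH3T3 cells with Urotensin-2 receptor (Homo sapiens) as the target; on this read-out higher numbers stand for larger maximal responses and lower numbers for smaller maximal responses. Compound 1 `Cc1ccccc1C(=O)NC(CCN(C)C)c1ccc(Cl)cc1` gives 175%, and compound 2 `COc1ccc(C(=O)NC(CCN(C)C)c2ccc(Cl)cc2)cc1` gives 162%. Compound 2 thus holds the lower of the two numbers. Within the data shown here, the only step measured so far, a number 13 percentage points lower from compound 1 to compound 2 (beyond the scatter), came from putting 4-methoxyphenyl in place of 2-methylphenyl on a carbonyl carbon, and it was modest.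

Compound 3 `CN(C)CCC(NC(=O)c1ccc(C(F)(F)F)cc1)c1ccc(Cl)cc1` differs from compound 2 in another way: trifluoromethyl in place of methoxy on an aromatic carbon. Among the measured compounds shown here, no measured step touches a trifluoromethyl group, so the single known step bears only loosely on this change. A step no larger than the usual scatter in this assay is therefore expected, with no clear direction. The expected step is a number 2 percentage points lower from compound 2 to compound 3 (within the scatter). Compound 3 is estimated at 160%, with a range from 130% to 190%.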

Compound 3, largest response reached (reported as efficacy), in percent of the reference or control that the assay uses: 115%
Estimate against measurement, compound 3: 45 percentage points above; measured number below the stated range.
By their numbers in this assay, from the lowest: compound 3; then compound 2; then compound 1.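

In this assay, among these compounds, the group on this aromatic carbon, para to a large group, carries far more weight than the earlier compounds suggested: a number 47 percentage points lower from compound 2 to compound 3 (beyond the scatter), a large step where a number 13 percentage points lower from compound 1 to compound 2 (beyond the scatter) was modest. The change swaps methoxy, with its one hydrogen-bond acceptor, for trifluoromethyl, with none, and it leaves compound 3 with the lowest number of the three at 115%. Nothing available here accounts for the size of this step.

Going by these compounds, it remains open whether a nitrile, an amine or a carboxylic acid on the same aromatic carbon would give a number nearer to that of compound 2 or that of compound 3. The compounds shown also cannot tell whether trifluoromethyl would have as large an effect elsewhere on this ring.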